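This account rests on a few compounds, and the source may have more. Where it says the series, first, only, none or still open, it means among the compounds named here.

Of the compounds shown here, three of a shared core have been measured in an assay on isolated protein for binding affinity to adenosine receptor A1 (Bos taurus); on this read-out lower numbers stand for stronger inhibition and higher numbers for weaker inhibition. Compound 1, with structure `CCCCCCNc1nc(-c2ccccc2)nc2c1nnn2Cc1ccccc1`, gives 13200000 nM. Compound 3, with structure `CNc1nc(-c2ccccc2)nc2c1nnn2Cc1ccccc1F`, gives 25000000 nM. Compound 2, with structure `CCNc1nc(-c2ccccc2)nc2c1nnn2Cc1ccccc1Cl`, gives 463000000 nM, the highest of the three numbers, meaning the weakest binding of the set; its nearest neighbour is compound 3, and both compounds 1 and 3 sit beyond the scatter from it. None of these pairs differs in only one place, so no single structural step can be read from them; compound 1 and compound 3 differ from compound 2 both in the chain on the nitrogen and elsewhere.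

Compound 4, with structure `Clc1ccccc1Cn1nnc2c(NC3CCCC3)nc(-c3ccccc3)nc21`, is not yet measured. Its change from compound 2 is cyclopentyl in place of ethyl on a nitrogen on an aromatic ring. For the measured compounds named here, with no measured pair showing this exact change, the expectation rests only on where compound 2 stands, at the weak end of the set with 463000000 nM. A step toward stronger binding, moderately beyond the scatter, is expected, giving an estimated 23-fold lower number from compound 2 to compound 4 (1.36 log units; beyond the scatter) in this assay . For compound 4 the expected value is 20000000 nM, with a range from 3000000 nM to 150000000 nM.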

Compound 4, inhibition constant: 9000000 nM
Compound 4: the middle estimate sits 2.2-fold (0.35 log units) above what was measured; the measured number falls inside the stated range.
By their numbers in this assay, from the lowest: compounds 4, 1 and 3 (each within the scatter of the next, the first and the last beyond it); then compound 2.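

In this assay, for the compounds shown here, replacing ethyl with cyclopentyl on a nitrogen on an aromatic ring gives the first step that can be read at this position: a 51-fold lower number from compound 2 to compound 4 (1.71 log units; beyond the scatter). The rest of the molecule stays the same in this pair. The change in number can be tied to this one place, and it shows that the group on this nitrogen can strongly affect binding in this assay, with the lower number meaning stronger binding. Nothing given here explains the size of this step, so the change from ethyl, with 2 heavy atoms, to cyclopentyl, with 5 heavy atoms and one five-membered non-aromatic ring, remains an observation without a known cause.

This single step cannot separate the effect of having more carbon from that of having a ring, a question that an open pentyl chain or a cyclohexyl ring on the same nitrogen would bear on. Going by these compounds alone, compounds 1 and 3 differ from compounds 2 and 4 in more than one place, so no steps involving them can be read, and whether the same change would have a similar effect on another version of the core stays open.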